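Replacing the Hydroxyphenyl Hydrazone with a Dimethoxyphenyl Analogue

A few compounds are considered here, and "the series" means these few. Any claim that something is new, unique, unknown or untested is made for them only; others in the source may bear on it.

Of the compounds shown here, three built on one shared core have been measured in a functional assay on the whole organism (strain Wistar) for inhibition, with Rattus norvegicus as the target, read by paw edema, with a stated time of 2 h, at a dose of 10 mg/kg by the intraperitoneal route; on this read-out higher numbers stand for more inhibition at the one dose given (going by the name of the read-out) and lower numbers for less inhibition. Compound 1 `O=C(N/N=C/c1ccccc1)c1cccnc1Nc1cccc(C(F)(F)F)c1` gives 36.8% in this assay, and compound 2 `O=C(N/N=C/c1ccc(F)cc1)c1cccnc1Nc1cccc(C(F)(F)F)c1` gives 41.2%, the two lying within the scatter of each other, as a number 4.4 percentage points higher from compound 1 to compound 2 (within the scatter) shows. Compound 3 `O=C(N/N=C/c1ccc(O)cc1)c1cccnc1Nc1cccc(C(F)(F)F)c1` gives 68% and stands highest of the three, beyond the scatter from both others: the gain a number 31.2 percentage points higher from compound 1 to compound 3 (beyond the scatter) is large, and the gain a number 26.8 percentage points higher from compound 2 to compound 3 (beyond the scatter) is modest. Compound 4 `COc1ccc(/C=N/NC(=O)c2cccnc2Nc2cccc(C(F)(F)F)c2)c(OC)c1` has not yet been measured. It differs from compound 3 in one place, (2,4-dimethoxyphenyl in place of 4-hydroxyphenyl on a carbon with a double bond to nitrogen), so the hydroxy that set compound 3 apart is gone and two methoxy groups take its place. For the measured compounds named here, no measured step covers a methoxy group; the steps that bear on the change are the two that brought in the hydroxy, a number 31.2 percentage points higher from compound 1 to compound 3 (beyond the scatter) and a number 26.8 percentage points higher from compound 2 to compound 3 (beyond the scatter), both beyond the scatter. Compound 4 lacks that hydroxy, and the expectation is that it falls back toward the level of compounds 1 and 2 rather than holding the level of compound 3, with the two methoxy groups an unknown that keeps the range wide. The step expected is a number 23 percentage points lower from compound 3 to compound 4 (beyond the scatter), downward and beyond the scatter. Compound 4 is therefore estimated at 45%, within a range from 30% to 62%.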

Compound 4, a percentage reported as inhibition, in the whole organism at one dose (the size of the read-out at that dose, not a potency): 44.7%
The estimate for compound 4 lay 0.3 percentage points above the measured number; the measured number falls inside the stated range.
By their numbers in this assay, from the lowest: compounds 1, 2 and 4 (each within the scatter of the next); then compound 3.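

In this assay the change from 4-hydroxyphenyl to 2,4-dimethoxyphenyl on a carbon with a double bond to nitrogen gives a number 23.3 percentage points lower from compound 3 to compound 4 (beyond the scatter), a modest step, so the level of compound 3 is not held once the hydroxy has left and two methoxy groups have entered. The same group set against the other two gives a number 3.5 percentage points higher from compound 2 to compound 4 (within the scatter) and a number 7.9 percentage points higher from compound 1 to compound 4 (within the scatter), so at this position phenyl, 4-fluorophenyl and 2,4-dimethoxyphenyl cannot be told apart, and among the four compounds only 4-hydroxyphenyl stands clear of the rest. Nothing measured here accounts for this difference.

Going by these compounds, since the hydroxy leaves and both methoxy groups enter in one step, the share of each in the loss cannot be separated, and how a phenyl carrying a single methoxy group would behave stays open. Also open, on these data alone, is whether an amine or a carboxylic acid in place of the hydroxy on the phenyl ring would reach the level of compound 3 or stay with compounds 1, 2 and 4.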